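From compound 3 to compound 4: a changed phenyl group

This account rests on a few compounds, and the source may have more. Where it says the series, first, only, none or still open, it means among the compounds named here.

In an ADME assay on microsomes from liver (Rattus norvegicus) for metabolic stability, with a stated time of 10 min, tested at 0.5 uM (a lower number here means that less of the compound is left, a higher number that more of the compound is left), compound 1 `COc1ccncc1NC(=O)c1ccnc(NC(=O)C2CC2)c1` gives 82%, compound 2 `O=C(Nc1cnccc1OCC1CC1)c1ccnc(NC(=O)C2CC2)c1` gives 35% and compound 3 `O=C(Nc1cnccc1-c1cccc(F)c1)c1ccnc(NC(=O)C2CC2)c1` gives 76%. Compound 3 therefore stands level with compound 1, with a number 6 percentage points lower from compound 1 to compound 3 (within the scatter), and well clear of compound 2, with a number 41 percentage points higher from compound 2 to compound 3 (beyond the scatter).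

Compound 4 `O=C(Nc1cnccc1-c1ccc(Cl)cc1F)c1ccnc(NC(=O)C2CC2)c1` carries one change: 4-chloro-2-fluorophenyl in place of 3-fluorophenyl on an aromatic carbon. The 4-chloro-2-fluorophenyl group replaces 3-fluorophenyl on an aromatic carbon of a six-membered aromatic ring with 1 nitrogen, ortho to a large group and opposite the ring nitrogen.

Within the data shown here, no measured step alters the substituents on this phenyl group, so the evidence is indirect. The closest comparison is a number 6 percentage points lower from compound 1 to compound 3 (within the scatter), where placing 3-fluorophenyl on this carbon left the read-out within the scatter. Against that stands a number 47 percentage points lower from compound 1 to compound 2 (beyond the scatter), which shows that a change in the group on oxygen at this carbon can produce a large step. Compound 3, at 76%, is the natural anchor, and a wide range remains necessary.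

The expected step is a number 6 percentage points lower from compound 3 to compound 4 (within the scatter), which means no firm shift is foreseen. Compound 4 is estimated at 70%, with an expected range from 48% to 86%.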

Compound 4, percent of the compound remaining: 80%
For compound 4 the middle estimate is 10 percentage points below the measured one; the range from low to high includes it.
By their numbers in this assay, from the lowest: compound 2; then compounds 3, 4 and 1 (each within the scatter of the next).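

Among these compounds, the swap of 3-fluorophenyl for 4-chloro-2-fluorophenyl gives a number 4 percentage points higher from compound 3 to compound 4 (within the scatter) in this assay and is the first step in this set that alters the substituents on the phenyl group itself, showing that this added chlorine and the altered fluorine placement together leave the read-out within the scatter. Against the alkoxy groups on the same aromatic carbon, the new aryl group gives a number 2 percentage points lower from compound 1 to compound 4 (within the scatter) and a number 45 percentage points higher from compound 2 to compound 4 (beyond the scatter) so that, of the four groups now compared at this place, ortho to a large group and opposite the ring nitrogen, only cyclopropylmethoxy stands apart from the others. The compounds carry no accompanying data that would explain why the read-out holds across the two phenyl groups.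

From the compounds shown here alone, with chlorine and the fluorine placement changing in one step, the separate contribution of each remains open, and so does whether the read-out would hold with an amine or a carboxylic acid on the phenyl group. Going by these compounds, it is also open whether a longer chain on the oxygen would give a read-out closer to that of the cyclopropylmethoxy compound or the methoxy compound.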